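A few compounds are considered here, and "the series" means these few. Any claim that something is new, unique, unknown or untested is made for them only; others in the source may bear on it.

Working notes on the series. For the measured compounds named here, in a functional assay on HeLa cells (Homo sapiens) for cytotoxicity, read by XTT assay, with a stated time of 72 h (on this read-out higher numbers stand for weaker inhibition and lower numbers for stronger inhibition), compound 1 `C=C1CC[C@H]2C(C)(C)CCC[C@]2(C)[C@H]1CC/C(C)=C/COc1c(-c2ccc(O)cc2)oc2cc(O)cc(O)c2c1=O` gives 27000 nM, the only actual number in the set. Compound 2 `CCCCCCCC/C=C\CCCCCCCCc1c(O)cc(O)c(C(C)=O)c1O` returns only a limit of the assay in this assay, > 100000 nM. Compound 3 `CC(=O)c1c(O)cc(O)cc1OCC=C(C)C` likewise returns a limit, > 100000 nM. Compound 1 thus stands alone as a measured value, set against (the limit of > 100000 nM in this assay, at which 2 of the 3 values shown sit). Compound 4 `C=C1CC[C@H]2C(C)(C)CCC[C@]2(C)[C@H]1CC/C(C)=C/COc1c(-c2ccc(OC)cc2)oc2cc(O)cc(O)c2c1=O` is not yet measured and differs from compound 1 by methyl in place of hydrogen on an oxygen on an aromatic ring. Going by the values given here, no step between measured compounds is available, so the size of this change cannot be read from the set itself. The expected step of a 1.3-fold higher number from compound 1 to compound 4 (0.11 log units; within the scatter) is small, toward weaker inhibition or none beyond the scatter. In this assay compound 4 is estimated at 35000 nM, with a range from 12000 nM to 100000 nM.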

Compound 4, half-maximal inhibitory concentration: 30000 nM
Estimate against measurement, compound 4: 1.2-fold (0.07 log units) above; the measured number falls inside the stated range.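

For the compounds shown here, on the 4-hydroxyphenyl group, methyl in place of hydrogen on the oxygen gives the first step that can be read: a 1.1-fold higher number from compound 1 to compound 4 (0.05 log units; within the scatter). In this assay, hydroxy and methoxy at this position therefore read alike, so the hydrogen on this oxygen is not needed to keep the measured level. Compound 2 and compound 3 still give a limit and not a number: the limit of > 100000 nM in this assay, at which 2 of the 4 values shown sit. From the compounds shown here alone, whether an ethyl ether, an amine or a carboxylic acid at this position would also read alike remains open.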